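Losing the (ethoxycarbonyl)methyl group from compound 3

The compounds below may be only part of what the source reports. "The series", "measured", "known", "first", "only" and "open" are said of these compounds alone.

Measured so far in a physicochemical assay for solubility, in phosphate buffer, with a stated time of 18 h, at pH 7.4; on this read-out higher numbers stand for higher solubility and lower numbers for lower solubility:
- compound 1 `Nc1nc(-c2ccccn2)nn1-c1ncnc2ccccc12`: 9000 nM
- compound 2 `Nc1nc(-c2ccccc2)nn1-c1ncnc2cc(Cl)ccc12`: 300 nM
- compound 3 `CCOC(=O)CNc1nc(-n2nc(-c3ccccn3)nc2N)c2cc(OC)c(OC)cc2n1`: 48000 nM

Compound 3, at 48000 nM, holds the highest number of the three, and its gaps to both others lie beyond the scatter. The next compound, compound 4 `COc1cc2nc(N)nc(-n3nc(-c4ccccn4)nc3N)c2cc1OC`, differs from it in one place: hydrogen in place of (ethoxycarbonyl)methyl on a nitrogen on an aromatic ring. In words, hydrogen stands in place of (ethoxycarbonyl)methyl on a nitrogen on an aromatic ring, which turns ((ethoxycarbonyl)methyl)amino into amino.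

Among the compounds with values here, no measured pair shows this change on its own, so any expectation is loose. Compound 1, which also lacks this group, gives 9000 nM, and compound 2, also without it, gives 300 nM. Both differ from compound 3 elsewhere too, so they suggest only a direction. A moderate fall in this assay is expected, and the estimated step is a 2.7-fold lower number from compound 3 to compound 4 (0.43 log units; beyond the scatter). For compound 4 the estimated value is 18000 nM, with an expected range from 5000 nM to 60000 nM.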

Compound 4, solubility: 27000 nM
The estimate for compound 4 lay 1.5-fold (0.18 log units) below the measured number; the measured number falls inside the stated range.
By their numbers in this assay, from the lowest: compound 2; then compound 1; then compounds 4 and 3 (each within the scatter of the next).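

Within the data shown here, the change of ((ethoxycarbonyl)methyl)amino to amino gives, in this assay, a 1.8-fold lower number from compound 3 to compound 4 (0.25 log units; within the scatter), and this is the first pair in which a single change can be read on its own. On this nitrogen on an aromatic ring, a group of 6 heavy atoms, including an ester, gives way to a lone hydrogen, and the two read-outs cannot be told apart. So, for this pair, the chain is not needed to keep the number where it stands, something compounds 1 and 2 could not show, as they differ from compound 3 in more than one place. Nothing measured here explains this result.

Still open, as far as these compounds go, is how other groups on this nitrogen would read, such as a methyl, a longer chain, a carboxylic acid in place of the ester, or a chain ending in an amine. Also open, from the compounds shown here alone, is whether the same change would read alike on a different core.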